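The compounds below may be only part of what the source reports. "The series", "measured", "known", "first", "only" and "open" are said of these compounds alone.

Three triazoles have been measured in a functional assay on the whole organism (Cricetulus griseus) with Cricetinae gen. sp. as the target; on this read-out higher numbers stand for an effect only at larger amounts of compound and lower numbers for an effect already at smaller amounts. Compound 1 `CCOc1cccc(-c2n[nH]c(-c3ccccc3C)n2)c1` gives 0.06 mg/kg, and compound 3 `CCOc1cccc(-c2n[nH]c(-c3ccccc3CC)n2)c1` gives 0.04 mg/kg; the change between them is methyl in place of hydrogen on a saturated chain carbon bound to an aromatic carbon, and it made a 1.5-fold lower number from compound 1 to compound 3 (0.18 log units; within the scatter). Compound 2 `C=CCOc1cccc(-c2nc(-c3ccccc3C)n[nH]2)c1` carries a different core, and the difference between the two cores is not broken down here; in this assay compound 2 gives 0.15 mg/kg, the highest of the three numbers, a gap to compounds 1 and 3 that lies beyond the scatter. Compound 4 `C=CCOc1cccc(-c2nc(-c3ccccc3CC)n[nH]2)c1` is not yet measured. It differs from compound 2 by methyl in place of hydrogen on a saturated chain carbon bound to an aromatic carbon, the same change that led from compound 1 to compound 3. Since that step was a 1.5-fold lower number from compound 1 to compound 3 (0.18 log units; within the scatter), a step of about a 1.5-fold lower number from compound 2 to compound 4 (0.18 log units; within the scatter) is expected here. Compound 4 is therefore estimated at 0.1 mg/kg, expected to fall between 0.05 mg/kg and 0.2 mg/kg.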

Compound 4, dose for half-maximal effect: 0.12 mg/kg
Compound 4: middle estimate off by 1.2-fold (0.08 log units), on the low side; the measured number falls inside the stated range.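

In this assay the new step is a 1.3-fold lower number from compound 2 to compound 4 (0.10 log units; within the scatter) and it sits close to the earlier one: the same change on two cores in this assay, a 1.5-fold lower number (0.18 log units; within the scatter) from compound 1 to compound 3 and a 1.3-fold lower number (0.10 log units; within the scatter) from compound 2 to compound 4, 1.2-fold (0.08 log units) apart, within the scatter of two such steps. The change of methyl to ethyl therefore read the same on the core of compound 1 and on the core of compound 2, as far as this scatter can tell. Each step also lies within the scatter on its own, which means the pair shows no real gain from the change on either core, and two cores say nothing about any further core.

The compounds shown leave open what a longer chain such as propyl, an amine or a carboxylic acid would do on a saturated chain carbon bound to an aromatic carbon. They also leave open how much of the gap between compound 1 and compound 2 belongs to the difference between their cores.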